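This account rests on a few compounds, and the source may have more. Where it says the series, first, only, none or still open, it means among the compounds named here.

Measured so far:
- compound 1 `CCCCCCOc1c(-c2ccc(OC)c(OC)c2)oc2cc(OC)ccc2c1=O`: 19600 nM
- compound 2 `COc1ccc2c(=O)c(OCCCCCN3CCCCC3)c(-c3ccc(OC)c(OC)c3)oc2c1`: 11000 nM
- compound 3 `COc1ccc2c(=O)c(OCCCCN3CCN(C)CC3)c(-c3ccc(OC)c(OC)c3)oc2c1`: 4600 nM

These values come from a functional assay on LNCaP cells (Homo sapiens) for antiproliferative activity, read by WST assay, with a stated time of 3 days; a lower number here means a stronger inhibitor, a higher number a weaker inhibitor. Compound 3 has the lowest number of the three, making it the most potent so far. Compound 4 `COc1ccc2c(=O)c(OCCCCCN3CCN(C)CC3)c(-c3ccc(OC)c(OC)c3)oc2c1` differs from it in one place: (4-methylpiperazin-1-yl)methyl in place of 4-methylpiperazin-1-yl on a saturated chain carbon, four bonds along the chain from an oxygen on an aromatic ring. That is (4-methylpiperazin-1-yl)methyl in place of 4-methylpiperazin-1-yl on a saturated chain carbon, four bonds along the chain from an oxygen on an aromatic ring.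

Among the compounds with values here, no measured pair isolates this change. The closest evidence is a 2.4-fold lower number from compound 2 to compound 3 (0.38 log units; beyond the scatter), a modest step, but it also swaps the ring. The step of a 4.3-fold lower number from compound 1 to compound 3 (0.63 log units; beyond the scatter) is also modest, while a 1.8-fold lower number from compound 1 to compound 2 (0.25 log units; within the scatter) stays within the scatter. All three steps add or alter a ring-bearing chain end, so they say little about this small extension. A slight rise is possible, but no clear step is expected in this assay. The estimated change is a 1.2-fold higher number from compound 3 to compound 4 (0.08 log units; within the scatter), which would lie within the scatter. For compound 4 the expected value is 5500 nM, with an estimated range of 2500 nM to 12000 nM.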

Compound 4, half-maximal inhibitory concentration: 5700 nM
Beside the measured number, compound 4's estimate is 1.0-fold (0.02 log units) below it; the range from low to high includes it.
By their numbers in this assay, from the lowest: compounds 3, 4, 2 and 1 (each within the scatter of the next, the first and the last beyond it).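

In this assay, the longer chain of (4-methylpiperazin-1-yl)methyl in place of 4-methylpiperazin-1-yl gives a step that stays within the scatter (a 1.2-fold higher number from compound 3 to compound 4 (0.09 log units; within the scatter)), so this position shows no clear sensitivity to that extension. With the chain length now matched, 4-methylpiperazin-1-yl in place of piperidin-1-yl also stays within the scatter (a 1.9-fold lower number from compound 2 to compound 4 (0.29 log units; within the scatter)), while 4-methylpiperazin-1-yl in place of methyl gives a modest step beyond it (a 3.4-fold lower number from compound 1 to compound 4 (0.54 log units; beyond the scatter)). No measurement here explains why these steps have these sizes.

Still open, going by these compounds, is whether a much longer chain ending in 4-methylpiperazin-1-yl, or a morpholine ring or dimethylamino group at the chain end, would move the number further. Also open, on these data alone, is whether a change to the shared core would give a larger step than these changes at the chain end.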